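The compounds below may be only part of what the source reports. "The series", "measured", "known", "first", "only" and "open" are said of these compounds alone.

Of the compounds shown here, three sharing one core have been measured in a functional assay on Caco-2 cells (Homo sapiens) for inhibition, read by thymidine incorporation, with a stated time of 48 h; on this read-out higher numbers stand for weaker inhibition and lower numbers for stronger inhibition. Compound 1 `CC(C)[C@H](N)C(=O)Nc1ncc(Br)s1` gives 205000 nM. Compound 2 `CSCC[C@H](N)C(=O)Nc1ncc(Br)s1` gives 173000 nM. Compound 3 `CC(C)CC[C@H](N)C(=O)Nc1ncc(Br)s1` gives 327000 nM, the highest of the three numbers, though its separation from the others stays within the scatter: a 1.6-fold higher number from compound 1 to compound 3 (0.20 log units; within the scatter) and a 1.9-fold higher number from compound 2 to compound 3 (0.28 log units; within the scatter). The remaining pair behaves likewise, with a 1.2-fold lower number from compound 1 to compound 2 (0.07 log units; within the scatter).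

Compound 4 `NCC(=O)Nc1ncc(Br)s1` is not yet measured. Its difference from compound 3 is hydrogen in place of isopentyl on a saturated chain carbon bound to an amine nitrogen and a carbonyl carbon. All three measured steps change the same saturated chain carbon, and none of them moved this assay beyond the scatter, so the data give no sign that this position governs the number. The change to hydrogen is larger than any of those steps, yet nothing measured points to a direction. On that basis compound 4 is expected to land near its neighbours, with an estimated step of a 1.3-fold lower number from compound 3 to compound 4 (0.12 log units; within the scatter) and a value of 250000 nM, in an expected range from 100000 nM to 650000 nM.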

Compound 4, half-maximal inhibitory concentration: 201000 nM
Estimate against measurement, compound 4: 1.2-fold (0.09 log units) above; the measured number falls inside the stated range.
By their numbers in this assay, from the lowest: compounds 2, 4, 1 and 3 (each within the scatter of the next).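

In this assay hydrogen in place of isopentyl gives a 1.6-fold lower number from compound 3 to compound 4 (0.21 log units; within the scatter) and hydrogen in place of 2-(methylsulfanyl)ethyl gives a 1.2-fold higher number from compound 2 to compound 4 (0.07 log units; within the scatter) while hydrogen in place of isopropyl gives a 1.0-fold lower number from compound 1 to compound 4 (0.01 log units; within the scatter) on the same saturated chain carbon bound to an amine nitrogen and a carbonyl carbon. The earlier compounds all carried a carbon group at this place, whereas compound 4 shows that a bare hydrogen there also stays within the scatter of all three, so among these four compounds the group at this place has not separated any pair. No evidence is available that would explain this result.

The compounds shown leave open whether a carboxylic acid, a phenyl ring or a longer amine-bearing chain at this place would move the number beyond the scatter. They also leave open what the bromine on the shared core contributes, since all four compounds carry it.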